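Benzothiazolyl replacement on the hydroxy compound

The source may hold more compounds than are shown below. What is called first, only, known or untested is meant among the compounds shown, and "the series" means these compounds.

Measured so far in a functional assay on HepG2 cells (Homo sapiens) for inhibition, read by MTT assay, with a stated time of 72 h; a lower number here means a stronger inhibitor, a higher number a weaker inhibitor:
- compound 1 `Brc1ccc(-c2nnc(SCCCN3CCN(c4nc5ccccc5o4)CC3)o2)cc1`: 67500 nM
- compound 2 `CC(C)(C)Oc1ccc(-c2nnc(SCCCN3CCN(c4nc5ccccc5o4)CC3)o2)cc1`: 121000 nM
- compound 3 `Oc1ccc(-c2nnc(SCCCN3CCN(c4nc5ccccc5o4)CC3)o2)cc1`: 502000 nM

Compound 3 has the highest number of the three, which makes it the weakest inhibitor here. Both of its steps lie beyond the scatter: a 7.4-fold higher number from compound 1 to compound 3 (0.87 log units; beyond the scatter) and a 4.1-fold higher number from compound 2 to compound 3 (0.62 log units; beyond the scatter). The remaining step, a 1.8-fold higher number from compound 1 to compound 2 (0.25 log units; within the scatter), stays within the scatter.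

Compound 4 `Oc1ccc(-c2nnc(SCCCN3CCN(c4nc5ccccc5s4)CC3)o2)cc1` keeps the hydroxy group of compound 3 and carries 1,3-benzothiazol-2-yl in place of 1,3-benzoxazol-2-yl on an amine nitrogen in a ring. Among the measured compounds shown here, no measured step touches this group, so there is no direct precedent. The three steps above bear only indirectly, as each concerns the group on the aromatic carbon, and the two involving compound 3 are modest in size. No clear shift is therefore expected in this assay, with a slight lean towards a lower number. The expected step is a 1.4-fold lower number from compound 3 to compound 4 (0.16 log units; within the scatter). For compound 4 the estimated value is 350000 nM, with an expected range of 110000 nM to 900000 nM.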

Compound 4, half-maximal inhibitory concentration: 364000 nM
Compound 4: the middle estimate sits 1.0-fold (0.02 log units) below what was measured, and the stated range covers the measured number.
By their numbers in this assay, from the lowest: compounds 1 and 2 (each within the scatter of the next); then compounds 4 and 3 (each within the scatter of the next).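

In this assay, among the compounds shown here, the first step at the group on the amine nitrogen in a ring is a 1.4-fold lower number from compound 3 to compound 4 (0.14 log units; within the scatter) and does not separate 1,3-benzothiazol-2-yl from 1,3-benzoxazol-2-yl on the hydroxy compound. The earlier steps shown here involving compound 3 all concern the group on the aromatic carbon and lie beyond the scatter, whereas this exchange of ring oxygen for ring sulfur does not, although that rests on a single pair. Nothing on hand offers an explanation for this result.

Going by these compounds, compounds 1 and 2 carry only 1,3-benzoxazol-2-yl, so it remains open whether 1,3-benzothiazol-2-yl behaves the same way alongside bromo or tert-butoxy. Also open, on these data alone, is what an amine or a carboxylic acid on the aromatic carbon would give in this assay.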